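The source may hold more compounds than are shown below. What is called first, only, known or untested is meant among the compounds shown, and "the series" means these compounds.

In a functional assay on MDA-MB-231 cells (Homo sapiens) for inhibition, read by sulforhodamine B assay, with a stated time of 48 h (on this read-out lower numbers stand for stronger inhibition of growth and higher numbers for weaker inhibition of growth), compound 1, with the structure `O=C(CCN1C(=O)CSc2ccccc21)N1CCN(c2ccccc2F)CC1`, gives 1600 nM. Compound 2, with the structure `O=C(CCN1C(=O)CSc2ccccc21)N1CCN(c2ccccc2)CC1`, differs from compound 1 by a single change, (hydrogen in place of fluoro on an aromatic carbon). In this assay compound 2 gives 5400 nM, and the step is a 3.4-fold higher number from compound 1 to compound 2 (0.53 log units; beyond the scatter).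

Compound 3 has the structure `O=C(CCN1C(=O)CSc2ccccc21)NCCCN1CCN(c2ccccc2F)CC1`. It carries the fluoro group of compound 1, but the difference between the core of compound 1 and the core of compound 3 is not broken down here. In this assay compound 3 gives 4600 nM. Its value lies near that of compound 2 and is within the scatter of it, while its number is higher than that of compound 1 by a gap that lies beyond the scatter.

Compound 4, with the structure `O=C(CCN1C(=O)CSc2ccccc21)NCCCN1CCN(c2ccccc2)CC1`, has not been measured. It is related to compound 3 by the same change that separates compound 1 from compound 2: hydrogen in place of fluoro on an aromatic carbon. On the earlier pair the change raised the number, and the only basis for an expectation is that one step. Compound 4 is therefore expected to show a step of about a 3.0-fold higher number from compound 3 to compound 4 (0.48 log units; beyond the scatter) in this assay, resting on the step seen from compound 1 to compound 2, a 3.4-fold higher number from compound 1 to compound 2 (0.53 log units; beyond the scatter), applied to the value of compound 3, 4600 nM. Compound 4 is thus estimated to give about 14000 nM in this assay, with a range from 6000 nM to 35000 nM expected.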

Compound 4, concentration for 50% growth inhibition: < 10 nM
Compound 4: a limit, no number; the forecaster's own chance of this, stated with the estimate: 15%; at least 1400-fold (3.14 log units) between middle value and limit.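

In this assay compound 4 gives < 10 nM, which is a limit of the assay and not a number, so the step that rests on it has no fixed size: the limit of < 10 nM in this assay, at which 1 of the 4 values shown sits. Hydrogen in place of fluoro gives an at least 460-fold lower number from compound 3 to compound 4 (2.66 log units; beyond the scatter), so the change that weakened growth inhibition on the core of compound 1 strengthens it on the core of compound 3, and the earlier step does not carry over to the second core: the same change on two cores in this assay, a 3.4-fold higher number (0.53 log units; beyond the scatter) from compound 1 to compound 2 and an at least 460-fold lower number (2.66 log units; beyond the scatter) from compound 3 to compound 4, at least 1500-fold (3.19 log units) apart, beyond the scatter of two such steps. Going by these compounds alone, this shows that neither the direction nor the size of the step can be taken from one core to the other, but it rests on only two pairs and does not show which feature of the two cores separates them, or why the change acts so differently on each.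

The compounds shown leave open whether the reversal is tied to fluoro alone or would also appear with chloro or methoxy on the same aromatic carbon in place of the 2-fluorophenyl group's fluoro. They also leave open whether a shorter or longer chain in the core of compound 3 would keep the strong inhibition seen with the phenyl group of compound 4.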